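Compound 3: The Same Molecule Drawn Without Its Configurations

The source may hold more compounds than are shown below. What is called first, only, known or untested is meant among the compounds shown, and "the series" means these compounds.

Of the compounds shown here, two have so far been measured in an assay on HEK293 cells for displacement of a labelled ligand from Neuronal acetylcholine receptor; alpha3/beta4 (Homo sapiens), read by scintillation counting; on this read-out higher numbers stand for weaker inhibition and lower numbers for stronger inhibition. Compound 1, `Oc1cncc(OC[C@@H]2CCCN2)c1`, gives 100 nM in this assay. Compound 2, `C[C@@H](Oc1ccccc1)[C@@H]1CCCN1C`, gives 1300 nM in this assay, the highest of the two numbers; the nearest is compound 1, whose number lies lower by a margin beyond the usual scatter. Compound 3, `CC(Oc1ccccc1)C1CCCN1C`, is not yet measured. Its relation to compound 2 is this: the two compounds have the same atoms and bonds; at least one stereo element is drawn with a configuration in one of them and without one in the other: 2 of 2 stereo elements differ; a stereocentre at a saturated chain carbon is drawn R in compound 2 and without a configuration in compound 3; a stereocentre at a saturated ring carbon is drawn S in compound 2 and without a configuration in compound 3. Compound 3 is thus the same substance drawn without its two configurations, standing for a mixture of stereoisomers, one of which is compound 2 itself. Among the compounds with values here, no step between measured compounds is available to guide the expectation. A mixture can at best match its most active component, so the number for compound 3 is expected to equal or somewhat exceed that of compound 2, with an expected step of a 1.7-fold higher number from compound 2 to compound 3 (0.23 log units; within the scatter), which may well stay within the scatter. Compound 3 is estimated at 2200 nM, within a range from 800 nM to 6500 nM.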

Compound 3, inhibition constant: 1400 nM
Compound 3: middle estimate off by 1.6-fold (0.20 log units), on the high side, and the stated range covers the measured number.
By their numbers in this assay, from the lowest: compound 1; then compounds 2 and 3 (each within the scatter of the next).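

In this assay, removing both drawn configurations comes with a 1.1-fold higher number from compound 2 to compound 3 (0.03 log units; within the scatter), so the two entries cannot be told apart. Within the data shown here, this is the first look at these two stereocentres, one at a saturated chain carbon and one at a saturated ring carbon, and on this read-out the defined drawing shows no measurable advantage over the undefined one. If compound 3 is truly a mixture of stereoisomers, the forms other than compound 2 would not be diluting the overall result by more than the scatter, but that reading stays conditional because the comparison rests only on how the two structures are drawn: the fact that one of compounds 2 and 3 is drawn with a defined configuration and the other without, at the place where they differ

From the compounds shown here alone, what remains open is how each single stereoisomer would behave on its own, and whether one form carries most of the inhibition seen for compound 3 or several forms contribute. Going by these compounds, it is also open whether a chlorine atom or an amide added to the shared core would leave the number just as unaffected by the drawn configurations.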